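This account rests on a few compounds, and the source may have more. Where it says the series, first, only, none or still open, it means among the compounds named here.

Measured so far in a functional assay on the whole organism (plasma, strain Wistar) with Rattus norvegicus as the target, with a stated time of 15 days, at a dose of 10 mg/kg by the oral route; on this read-out lower numbers stand for a weaker effect and higher numbers for a stronger effect at the one dose given:
compound 1, `Cc1ccc(-c2nnc(SCCOc3ccc(/C=C4\SC(=O)NC4=O)cc3)[nH]2)cc1`: 20.4%
compound 2, `O=C1NC(=O)/C(=C/c2ccc(OCCSc3nnc(-c4ccccc4[N+](=O)[O-])[nH]3)cc2)S1`: 15.3%

For the measured compounds named here, compound 2 holds the lowest of the two numbers in this assay; its only neighbour is compound 1, and the gap a number 5.1 percentage points lower from compound 1 to compound 2 (within the scatter) lies within the scatter, so the two values cannot be put in order.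

Compound 3, `O=C1NC(=O)/C(=C/c2ccc(OCCSc3nnc(-c4ccc(Br)cc4)[nH]3)cc2)S1`, differs from compound 2 in one place: 4-bromophenyl in place of 2-nitrophenyl on an aromatic carbon

Going by the values given here, the only measured step, a number 5.1 percentage points lower from compound 1 to compound 2 (within the scatter), also swapped the aryl group on the same aromatic carbon of the shared core and stayed within the scatter. Among the compounds with values here, no measured step involves 4-bromophenyl, so nothing in the data points to a shift in either direction. The expected step is therefore none beyond the scatter, a number 2.7 percentage points higher from compound 2 to compound 3 (within the scatter). Compound 3 is estimated at 18% in this assay, with a range from 8% to 30%.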

Compound 3, a percentage reported as activity, at one dose (the size of the read-out at that dose, not a potency): 20.4%
The estimate for compound 3 lay 2.4 percentage points below the measured number; measured number inside the range.
By their numbers in this assay, from the lowest: compounds 2, 1 and 3 (each within the scatter of the next).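

In this assay, the exchange of 2-nitrophenyl for 4-bromophenyl on this aromatic carbon of the five-membered aromatic ring gives a number 5.1 percentage points higher from compound 2 to compound 3 (within the scatter), although the entering group has 0 hydrogen-bond acceptors against 2 in the group that leaves. Bromo in place of methyl on the aromatic carbon of the phenyl group gives no change at the digits printed from compound 1 to compound 3 (within the scatter), so the three aryl groups shown, including the first with a halogen, cannot be told apart in this read-out. Nothing available bears on the reason for these values.

Open, going by these compounds, is whether an aryl group carrying an amine or a carboxylic acid, or a saturated ring such as cyclohexyl at this position, would give a step beyond the scatter. Also open, on these data alone, is whether a longer chain between the shared core's two ring systems would do so.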